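The source may hold more compounds than are shown below. What is called first, only, known or untested is meant among the compounds shown, and "the series" means these compounds.

Compound 1 `NC(=S)N/N=C/c1cc2cccnc2s1`: > 100000 nM
Compound 2 `N#Cc1ccc(NC(=S)N/N=C/c2ccc3ccccc3n2)cc1`: 15600 nM
Compound 3 `Cc1ccc(NC(=O)N/N=C/c2ccc3ccccc3n2)cc1`: > 100000 nM

Of the compounds shown here, three have been tested in a functional assay on HT-29 cells (Homo sapiens) for antiproliferative activity, read by sulforhodamine B assay, with a stated time of 72 h; a higher number here means a weaker inhibitor, a lower number a stronger inhibitor. Only compound 2 gives a number there, with 15600 nM. For compound 1 the result is a limit, > 100000 nM, not a number. For compound 3 the result is likewise a limit, > 100000 nM. Among the compounds with values here, two of the three results therefore sit at the limit of > 100000 nM in this assay, at which 2 of the 3 values shown sit, so compound 2 is the only compound whose strength can be placed at all, and it is the natural starting point for a further change.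

Compound 4 `S=C(N/N=C/c1ccc2ccccc2n1)Nc1ccc(Br)cc1` has not yet been measured. It differs from compound 2 in one place: bromo in place of cyano on an aromatic carbon. Within the data shown here, no pair of measured compounds differs in one place, so there is no measured step to lean on.

For the change from compound 2 to compound 4 a small step is expected, within or barely beyond the usual scatter, with no clear direction, giving a 1.3-fold lower number from compound 2 to compound 4 (0.11 log units; within the scatter). Compound 4 is therefore expected to give 12000 nM in this assay, in the range 3500 nM to 45000 nM.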

Compound 4, half-maximal inhibitory concentration: 54400 nM
For compound 4 the middle estimate is 4.5-fold (0.66 log units) below the measured one, and the stated range ends below it.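

In this assay, within the data shown here, replacing 4-cyanophenyl with 4-bromophenyl gives a 3.5-fold higher number from compound 2 to compound 4 (0.54 log units; beyond the scatter) and this is the first step that can be read as a number at both ends. It shows that the group at this place on the aromatic ring matters for this read-out, and that the compound with the nitrile has the lower number of the two, which makes it the stronger inhibitor in this pair. Among these compounds, the results for compound 1 and compound 3 remain limits, not numbers, so they add no further step: the limit of > 100000 nM in this assay, at which 2 of the 4 values shown sit.

A single step cannot show why the number rises when bromo replaces cyano. It also leaves open how other groups in the same place, such as an amine, a carboxylic acid or a longer chain, would compare.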